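A few compounds are considered here, and "the series" means these few. Any claim that something is new, unique, unknown or untested is made for them only; others in the source may bear on it.

Measured in an ADME assay on HepG2 cells (Homo sapiens) for cytotoxicity, read by CellTiter-Glo, with a stated time of 72 h; a lower number here means that less compound is needed, a higher number that more compound is needed for the effect:
- Compound 1 `CC1=C2CC(C)(C)/C=C/C/C(C)=C\C3=C[C@H](C)C[C@]3(O2)C1=O`: 26000 nM
- Compound 2 `CC(=O)O[C@H]1/C=C/C(C)(C)CC2=C(C)C(=O)[C@]3(C[C@@H](C)C=C3/C=C\1C)O2`: 26000 nM
- Compound 3 `CC1=C2CC(C)(C)/C=C/[C@@H](O)/C(C)=C\C3=C[C@H](C)C[C@]3(O2)C1=O`: 26000 nM

All three compounds give the same number, so compound 3, at 26000 nM, stands level with the other two. The next compound to consider is compound 4 `CC(=O)O[C@@H]1/C=C/C(C)(C)CC2=C(C)C(=O)[C@]3(C[C@@H](C)C=C3/C=C\1C)O2`. It is compound 3 with acetyl in place of hydrogen on an oxygen on a saturated carbon, which turns a hydroxy group into an acetoxy group: acetyl in place of hydrogen on an oxygen on a saturated carbon.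

For the measured compounds named here, two measured steps bear on this change. Putting a hydroxy group in place of hydrogen on a saturated ring carbon gave no change at the digits printed from compound 1 to compound 3 (within the scatter). Putting an acetoxy group in place of hydrogen on a saturated ring carbon gave no change at the digits printed from compound 1 to compound 2 (within the scatter). Neither edit moved the number in this assay, and the two end points share the same value. Going by the values given here, no measured step starts from a hydroxy compound and adds acetyl to it, so this support is indirect. Even so, nothing here points to a shift in either direction, and no move beyond the scatter is expected. The expected result is no change at the digits printed from compound 3 to compound 4 (within the scatter).

For compound 4, the estimated value is 26000 nM, with an expected range of 14000 nM to 45000 nM.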

Compound 4, half-maximal effective concentration: 26000 nM
Compound 4: the middle estimate sits on the measured number at the digits printed, within the range that was stated.
By their numbers in this assay, from the lowest: compounds 1, 2, 3 and 4 (each within the scatter of the next).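

In this assay, the edit itself, acetyl in place of hydrogen on an oxygen on a saturated carbon, gave no change at the digits printed from compound 3 to compound 4 (within the scatter), so the hydroxy to acetoxy change now rests on a directly measured pair rather than on two separate steps from compound 1. For the compounds shown here, compound 4 also brings the first comparison of configuration at this position, where a saturated ring carbon is drawn S in compound 2 and R in compound 4, and the result is no change at the digits printed from compound 2 to compound 4 (within the scatter), a reading that holds for this pair on one condition: the fact that compounds 2 and 4 differ only in the configuration as drawn Measured against the compound without any group at this carbon, the R-drawn acetoxy compound gave no change at the digits printed from compound 1 to compound 4 (within the scatter), so neither drawn form of the acetoxy group separates from compound 1 in this assay.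

From the compounds shown here alone, whether a larger ester such as benzoyl, or an amine at this carbon, would move the number remains open. All four compounds share one value, so they show no change at this position that shifts the result, and they say nothing about which parts of the shared core the value depends on.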